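The source may hold more compounds than are shown below. What is called first, only, known or untested is meant among the compounds shown, and "the series" means these compounds.

Compound 1 `CCOC(=O)c1sc(-c2cccc(NC(=O)c3ccc(C(F)(F)F)cc3)c2)nc1Nc1ccc(N2CCN(C)CC2)cc1`: 18.4%
Compound 2 `CCOC(=O)c1sc(-c2cccc(NC(=O)c3cccc(F)c3)c2)nc1Nc1ccc(N2CCN(C)CC2)cc1`: 85.2%
Compound 3 `CCOC(=O)c1sc(-c2cccc(NC(=O)c3ccccc3F)c2)nc1Nc1ccc(N2CCN(C)CC2)cc1`: 96.4%

In a functional assay on Ramos cells (Homo sapiens) for antiproliferative activity, read by CCK-8 assay, with a stated time of 72 h, tested at 40 uM (a lower number here means less inhibition, a higher number more inhibition at the concentration tested (going by the name of the read-out)), compound 3 gives the highest of these three numbers. The nearest step to it is a number 11.2 percentage points higher from compound 2 to compound 3 (beyond the scatter), the widest is a number 78 percentage points higher from compound 1 to compound 3 (beyond the scatter). Compound 4 `CCOC(=O)c1sc(-c2cccc(NC(=O)c3ccc(C(F)(F)F)cn3)c2)nc1Nc1ccc(N2CCN(C)CC2)cc1` differs from compound 3 by 5-(trifluoromethyl)pyridin-2-yl in place of 2-fluorophenyl on a carbonyl carbon. The step that bears on this change is a number 78 percentage points higher from compound 1 to compound 3 (beyond the scatter), since compound 1 carries a 4-(trifluoromethyl)phenyl on the same carbonyl carbon and gives a far lower number. Compound 4 brings a trifluoromethyl group back on that ring, though now a ring with one hetero atom, so a large fall is expected: a number 61.4 percentage points lower from compound 3 to compound 4 (beyond the scatter). Compound 4 is estimated at 35%, with a wide range from 10% to 70%.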

Compound 4, a percentage reported as inhibition, at one concentration (the size of the read-out at that concentration, not a potency): 19%
Compound 4: middle estimate off by 16 percentage points, on the high side, within the range that was stated.
By their numbers in this assay, from the lowest: compounds 1 and 4 (each within the scatter of the next); then compound 2; then compound 3.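

In this assay the fall a number 77.4 percentage points lower from compound 3 to compound 4 (beyond the scatter) and the fall a number 66.2 percentage points lower from compound 2 to compound 4 (beyond the scatter) show that 5-(trifluoromethyl)pyridin-2-yl on this carbonyl carbon does not keep the high numbers of the two fluorophenyl compounds. The step of a number 0.6 percentage points higher from compound 1 to compound 4 (within the scatter) shows that the two trifluoromethyl compounds cannot be told apart, even though one ring holds a hetero atom and the other holds carbon only. Nothing measured here gives a reason for this. Still open, as far as these compounds go, is how a pyridin-2-yl ring carrying only fluorine, or a methyl group on that ring, would behave at this position.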